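The compounds below may be only part of what the source reports. "The series", "measured", "known", "first", "only" and "open" are said of these compounds alone.

Working notes on the series: in a functional assay on COLO 205 cells (Homo sapiens) for inhibition, read by sulforhodamine B assay, with a stated time of 48 h, tested at 50 uM (on this read-out higher numbers stand for more inhibition of growth at the one concentration tested and lower numbers for less inhibition of growth), compound 1 `COc1cc(/C=C/C(=O)/C=C/c2ccccc2)ccc1OCc1cn(CCOc2cc(=O)oc3ccccc23)nn1` gives 54% and compound 2 `COc1cc(/C=C/C(=O)/C=C/c2ccco2)ccc1OCc1cn(CCOc2cc(=O)oc3ccccc23)nn1` gives 68%, so compound 2 holds the higher of the two numbers so far. The next compound is compound 3 `COc1ccccc1/C=C/C(=O)/C=C/c1ccc(OCc2cn(CCOc3cc(=O)oc4ccccc34)nn2)c(OC)c1`, which differs from compound 2 as follows: 2-methoxyphenyl in place of furan-2-yl on a double-bonded chain carbon bound to a double-bonded chain carbon. In words, 2-methoxyphenyl stands in place of furan-2-yl on a double-bonded chain carbon bound to a double-bonded chain carbon. Within the data shown here, only one measured step bears on this place: a number 14 percentage points higher from compound 1 to compound 2 (beyond the scatter), a modest step on going from phenyl to furan-2-yl. Among the measured compounds shown here, no measured compound carries 2-methoxyphenyl, so the reverse of that step is only a rough guide. A modest fall of similar size is expected in this assay, and the expected change is a number 12 percentage points lower from compound 2 to compound 3 (beyond the scatter). For compound 3 the estimated value is 56%, with an expected range of 40% to 72%.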

Compound 3, percent growth inhibition at one concentration: 67%
Compound 3: the middle estimate sits 11 percentage points below what was measured; measured number inside the range.
By their numbers in this assay, from the lowest: compound 1; then compounds 3 and 2 (each within the scatter of the next).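

In this assay the exchange at this place gives a number 1 percentage points lower from compound 2 to compound 3 (within the scatter), so furan-2-yl is not required for the higher reading: a six-membered aromatic ring of carbon only, carrying methoxy, serves as well. Methoxy in place of hydrogen on an aromatic carbon gives a number 13 percentage points higher from compound 1 to compound 3 (beyond the scatter), which means that a plain phenyl is not the limit for a six-membered ring here and that the ring can be changed with a gain. Nothing available on these compounds accounts for either step.

On these data alone, whether the gain depends on methoxy itself, or would also appear with a hydroxyl, a dimethylamino group or a carboxylic acid on that phenyl, stays open. As far as these compounds go, with a read-out at one concentration, it also stays open how compound 2 and compound 3 would compare across a range of concentrations.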